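The compounds below may be only part of what the source reports. "The series", "measured", "known", "first", "only" and "open" are said of these compounds alone.

Working notes on the series. Of the compounds shown here, three so far have numbers in an in vitro ADME assay on microsomes from liver (Homo sapiens) for metabolic stability; on this read-out lower numbers stand for slow clearance and higher numbers for fast clearance. Compound 1 `CC(C)Nc1nccc(-c2c[nH]nc2C2CCCCO2)n1` gives 0.021 mL/min/kg, compound 2 `CS(=O)(=O)N[C@H]1CC[C@H](c2n[nH]cc2-c2ccnc(NC3CCCC3)n2)CC1` gives 0.011 mL/min/kg, and compound 3 `CC(C)Nc1nccc(-c2c[nH]nc2C2CCN(S(C)(=O)=O)CC2)n1` gives 0.012 mL/min/kg. These three values lie within the scatter of one another, so compound 1 stands level with compound 2 and compound 3, and no ranking can be drawn among them.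

Compound 4 `CC(C)Nc1nccc(-c2cn[nH]c2)n1` has not yet been measured in this assay. Going from compound 1 to compound 4, the change is hydrogen in place of oxan-2-yl on an aromatic carbon of a five-membered aromatic ring with 2 nitrogen.

Among the measured compounds shown here, no two measured compounds differ in one place only, so the series offers no direct precedent for the size of this change. For the measured compounds named here, the only guide is the narrow spread of the measured values, with compound 3 at 0.012 mL/min/kg and compound 1 at 0.021 mL/min/kg sitting within the scatter despite their different groups. No step beyond the scatter is therefore expected in either direction. The expected step, a 1.4-fold lower number from compound 1 to compound 4 (0.15 log units; within the scatter), stays within the scatter. For compound 4 the estimated clearance is 0.015 mL/min/kg, with an expected range from 0.007 mL/min/kg to 0.03 mL/min/kg.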

Compound 4, clearance: 0.021 mL/min/kg
The estimate for compound 4 lay 1.4-fold (0.15 log units) below the measured number; the measured number falls inside the stated range.
By their numbers in this assay, from the lowest: compounds 2, 3, 1 and 4 (each within the scatter of the next).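

Hydrogen in place of oxan-2-yl on an aromatic carbon of the five-membered aromatic ring with 2 nitrogen gives, in this assay, no change at the digits printed from compound 1 to compound 4 (within the scatter), and this is the first comparison in the series that isolates a single place. Among the compounds shown here, at this carbon, then, the whole oxan-2-yl group, with its 6 heavy atoms, its non-aromatic ring and its hydrogen-bond acceptor, can leave without a step beyond the scatter, something the earlier compounds, which differ in more than one place, could not show. No measurement at hand bears on why the read-out holds steady across this change.

For the compounds shown here, open is whether any group on this carbon moves the clearance beyond the scatter, for example a primary amine, a carboxylic acid or a longer alkyl chain, since the one step available spans only hydrogen and oxan-2-yl. Equally open, as far as these compounds go, is whether the same replacement gives so small a step on a different core, such as that of compound 2.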